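Swapping the benzyl substituent at the assay limit

This account rests on a few compounds, and the source may have more. Where it says the series, first, only, none or still open, it means among the compounds named here.

In a functional assay on MCF cells (Homo sapiens) for antiproliferative activity, with a stated time of 72 h (on this read-out lower numbers stand for stronger inhibition and higher numbers for weaker inhibition), compound 3 (`COc1cc(CNc2ncnc3c2ncn3[C@@H]2O[C@H](CO)[C@@H](O)[C@H]2O)cc(OC)c1`) reads only as a limit (> 166000 nM). Compound 1 (`Cc1cccc(CNc2ncnc3c2ncn3[C@@H]2O[C@H](CO)[C@@H](O)[C@H]2O)c1`) is also a limit (> 166000 nM). Compound 2 (`Cc1ccc(CNc2ncnc3c2ncn3[C@@H]2O[C@H](CO)[C@@H](O)[C@H]2O)cc1`) is likewise a limit (> 166000 nM). All measurements so far therefore sit at one value (the limit of > 166000 nM in this assay, at which 3 of the 3 values shown sit). Compound 4 (`OC[C@H]1O[C@@H](n2cnc3c(NCc4ccc(F)cc4F)ncnc32)[C@H](O)[C@@H]1O`) carries 2,4-difluorophenyl in place of 3,5-dimethoxyphenyl on a saturated chain carbon bound to a nitrogen on an aromatic ring. Going by the values given here, two measured steps bear on this change (a step that the two limits leave unreadable from compound 1 to compound 3 and a step that the two limits leave unreadable from compound 2 to compound 3), and neither has a readable size. Among the compounds with values here, no step of definite size or direction is therefore expected in this assay for this change. The estimate implies only an expected small change (a step that the limit leaves unreadable from compound 3 to compound 4). For compound 4 the expected value is 170000 nM (estimated range 70000 nM to 300000 nM), most likely reported as a limit again.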

Compound 4, half-maximal inhibitory concentration: > 166000 nM
Compound 4: only a limit was reported; the forecaster's own chance of this, stated with the estimate: 80%; the middle value lies beyond the limit too.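

In this assay compound 4 gives > 166000 nM, a limit, so its steps from compound 1, compound 2 and compound 3 cannot be read. The compounds shown leave open whether any aryl group on the saturated chain carbon gives a measurable value.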